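Ester in place of hydroxyether at the side-chain oxygen

A few compounds are considered here, and "the series" means these few. Any claim that something is new, unique, unknown or untested is made for them only; others in the source may bear on it.

Measured in a functional assay on HeLa cells (Homo sapiens) for cytotoxicity, read by MTT assay; on this read-out higher numbers stand for weaker inhibition and lower numbers for stronger inhibition:
compound 1 `CC(C)=CC[C@@H](OC(=O)c1ccoc1)C1=CC(=O)c2c(O)ccc(O)c2C1=O`: > 100000 nM, a limit of the assay rather than a number
compound 2 `CC(C)=CC[C@@H](OC[C@@H](C)O)C1=CC(=O)c2c(O)ccc(O)c2C1=O`: 22500 nM
compound 3 `COC(C)CO[C@H](CC=C(C)C)C1=CC(=O)c2c(O)ccc(O)c2C1=O`: 53400 nM

Compound 2 has the lowest of the two plain numbers shown; compound 3 lies a 2.4-fold higher number from compound 2 to compound 3 (0.38 log units; beyond the scatter). Compound 1 gives only a limit, (the limit of > 100000 nM in this assay, at which 1 of the 3 values shown sits).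

Compound 4 `CC(C)=CC[C@@H](OC(=O)C1CCOC1)C1=CC(=O)c2c(O)ccc(O)c2C1=O` differs from compound 2 in one place: (oxolan-3-yl)carbonyl in place of 2-hydroxypropyl on an oxygen on a saturated carbon.

Going by the values given here, the step that bears on this is the one between compound 1 and compound 2, an at least 4.4-fold lower number from compound 1 to compound 2 (0.64 log units; beyond the scatter), where the same oxygen carried a (furan-3-yl)carbonyl and the number sat at the limit. Compound 4 again carries a carbonyl-linked five-membered ring on that oxygen, now the oxolane, and the 2-hydroxypropyl with its one hydrogen-bond donor is lost. The expected change is therefore a higher number, a 3.6-fold higher number from compound 2 to compound 4 (0.55 log units; beyond the scatter), possibly reaching the limit again. For compound 4 the estimate is 80000 nM, with a range from 30000 nM to 200000 nM.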

Compound 4, half-maximal inhibitory concentration: 73500 nM
The estimate for compound 4 lay 1.1-fold (0.04 log units) above the measured number; low and high end bracket the measured number.
By their numbers in this assay, from the lowest: compound 2; then compounds 3 and 4 (each within the scatter of the next). At a limit, above all of these: compound 1.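

In this assay, the ester carrying a saturated ring gives a measurable number, but it does not match the 2-hydroxypropyl ether: a 3.3-fold higher number from compound 2 to compound 4 (0.51 log units; beyond the scatter). The ester does not separate from the 2-methoxypropyl ether: a 1.4-fold higher number from compound 3 to compound 4 (0.14 log units; within the scatter), so among the plain numbers at this oxygen only compound 2 stands apart. Oxolan-3-yl in place of furan-3-yl reads an at least 1.3-fold lower number from compound 1 to compound 4 (0.13 log units; that floor lies within the scatter); the compound 1 end of this step is a limit, so the size of that swap cannot be read.

Going by these compounds, it remains open whether a 2-aminopropyl or a longer chain such as 3-hydroxypropyl on this oxygen would give a lower number than compound 2 at 22500 nM. On these data alone, it is also open how an amide linking the oxolane would compare with the ester of compound 4.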